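The source may hold more compounds than are shown below. What is called first, only, known or untested is meant among the compounds shown, and "the series" means these compounds.

Compound 1 `CCCCCCCCNC(=O)[C@@H](NC(=O)/C=C/c1ccccc1)[C@@H](C)O` is the reference point of this small set. In a functional assay on SW-620 cells (Homo sapiens) for cytotoxicity, read by MTT assay, with a stated time of 48 h (a lower number here means a stronger inhibitor, a higher number a weaker inhibitor), compound 1 gives 61400 nM. Compound 2 `C/C=C/C=C/C(=O)N[C@H](C(=O)NCCCCCCCC)[C@@H](C)O` carries the change (prop-1-en-1-yl in place of phenyl on a double-bonded chain carbon bound to a double-bonded chain carbon), and in this assay compound 2 gives 200000 nM; the step is a 3.3-fold higher number from compound 1 to compound 2 (0.51 log units; beyond the scatter). Compound 3 `CCCCCCCCCCCCNC(=O)[C@@H](NC(=O)/C=C/c1ccccc1)[C@@H](C)O` differs from compound 1 by butyl in place of hydrogen on a saturated chain carbon, eight bonds along the chain from an amide-type nitrogen, which is how the two cores differ, and in this assay compound 3 gives 200000 nM; the step is a 3.3-fold higher number from compound 1 to compound 3 (0.51 log units; beyond the scatter). Compound 2 and compound 3 sit level at the digits reported, so no order between them can be read.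

Compound 4 `C/C=C/C=C/C(=O)N[C@H](C(=O)NCCCCCCCCCCCC)[C@@H](C)O` is not yet measured. It differs from compound 3 by prop-1-en-1-yl in place of phenyl on a double-bonded chain carbon bound to a double-bonded chain carbon, the same change that separates compound 1 from compound 2, made on the core of compound 3. The earlier step gave a 3.3-fold higher number from compound 1 to compound 2 (0.51 log units; beyond the scatter). Since compound 3 already stands where compound 2 does, and because the earlier step was a 3.3-fold higher number from compound 1 to compound 2 (0.51 log units; beyond the scatter), compound 4 is expected to fall at or past the weak end, with an expected step of a 1.8-fold higher number from compound 3 to compound 4 (0.24 log units; within the scatter). Compound 4 is therefore estimated at 350000 nM, between 180000 nM and 900000 nM.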

Compound 4, half-maximal inhibitory concentration: 200000 nM
The estimate for compound 4 lay 1.8-fold (0.24 log units) above the measured number; the measured number falls inside the stated range.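

In this assay, prop-1-en-1-yl in place of phenyl on the core of compound 3 gives no change at the digits printed from compound 3 to compound 4 (within the scatter), and butyl in place of hydrogen on a saturated chain carbon, eight bonds along the chain from an amide-type nitrogen, gives no change at the digits printed from compound 2 to compound 4 (within the scatter). The size of the first change therefore did not carry from one core to the other: the same change on two cores in this assay, a 3.3-fold higher number (0.51 log units; beyond the scatter) from compound 1 to compound 2 and no change at the digits printed (within the scatter) from compound 3 to compound 4, 3.3-fold (0.51 log units) apart, beyond the scatter of two such steps The second change behaved in the same way, which shows that the size of each step depended on the core in these four compounds, but not why it did or how either change would behave on any further core: the same change on two cores in this assay, a 3.3-fold higher number (0.51 log units; beyond the scatter) from compound 1 to compound 3 and no change at the digits printed (within the scatter) from compound 2 to compound 4, 3.3-fold (0.51 log units) apart, beyond the scatter of two such steps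

Compound 2, compound 3 and compound 4 stand level at the digits printed, so these compounds give no order among them. As far as these compounds go, how the numbers would run with a decyl chain in place of the chain of compound 1, or with an amine or a carboxylic acid in place of phenyl, remains open.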